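The source may hold more compounds than are shown below. What is called first, only, known or untested is meant among the compounds shown, and "the series" means these compounds.

Measured in a functional assay on A549 cells (Homo sapiens) for cytotoxicity, read by MTT assay, with a stated time of 48 h; a higher number here means a weaker inhibitor, a lower number a stronger inhibitor:
- Compound 1 `COc1cc(-c2noc(N)c2-c2ccc(Cl)cc2)cc(OC)c1OC`: > 50000 nM (a limit)
- Compound 2 `COc1ccc(-c2c(-c3cc(OC)c(OC)c(OC)c3)noc2NC(C)=O)cc1OC`: 19800 nM

For the measured compounds named here, only two compounds have been tested in this assay, and compound 2 holds the sole actual number, 19800 nM. Compound 1 gives no number, and its > 50000 nM is a limit of the assay.

Compound 3 `COc1cc(-c2noc(NC(C)=O)c2-c2ccc(Cl)cc2)cc(OC)c1OC` has not yet been measured. It keeps the acetamido group of compound 2 but carries 4-chlorophenyl in place of 3,4-dimethoxyphenyl on an aromatic carbon.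

Going by the values given here, no step between measured compounds shows what such a change does, so any expectation rests on thin ground. Compound 1 also bears a 4-chlorophenyl, and its reading is the limit of > 50000 nM in this assay, at which 1 of the 2 values shown sits. That leans the expectation towards weaker inhibition in this assay, though only slightly. The expected step is a 1.6-fold higher number from compound 2 to compound 3 (0.21 log units; within the scatter), which may not go beyond the usual scatter. A limit rather than a number is also a real possibility for this compound. For compound 3 the estimated value is 32000 nM, with an expected range of 12000 nM to 70000 nM.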

Compound 3, half-maximal inhibitory concentration: 25000 nM
The estimate for compound 3 lay 1.3-fold (0.11 log units) above the measured number; low and high end bracket the measured number.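

In this assay, 4-chlorophenyl in place of 3,4-dimethoxyphenyl on this aromatic carbon of the five-membered ring gives a 1.3-fold higher number from compound 2 to compound 3 (0.10 log units; within the scatter), so at this position the two groups cannot be told apart in this read-out, even though the hydrogen-bond acceptors of the group that leaves are gone. With 4-chlorophenyl held in place, acetyl in place of hydrogen on the nitrogen gives an at least 2.0-fold lower number from compound 1 to compound 3 (0.30 log units; that floor lies within the scatter), which is only a floor and does not establish that the acetyl group makes any difference. The reading of compound 1 is a limit and not a number, so this floor cannot be sharpened from the values shown: the limit of > 50000 nM in this assay, at which 1 of the 3 values shown sits.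

What the compounds shown leave open is whether another group at this position, such as a plain phenyl, a 4-fluorophenyl or a pyridyl ring, would move the number beyond the scatter. On these data alone, it is equally open whether a longer acyl chain such as butanoyl, or a methanesulfonyl group, on the nitrogen would do so, and whether the free amine and the acetamido group differ when 3,4-dimethoxyphenyl is present.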